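A few compounds are considered here, and "the series" means these few. Any claim that something is new, unique, unknown or untested is made for them only; others in the source may bear on it.

In a functional assay on cells (leukaemia cell line, Homo sapiens) for inhibition, read by sulforhodamine B assay, with a stated time of 48 h (on this read-out lower numbers stand for higher toxicity in this test and higher numbers for lower toxicity in this test), compound 1 (`O=S(=O)(Nc1ccc(Br)c(Cl)c1)c1ccc(-c2cnc(C3CC3)o2)cc1`) shows only a limit (> 100000 nM). Compound 2 (`Cc1ccc(Cl)c(NS(=O)(=O)c2ccc(-c3cnc(C4CC4)o3)cc2)c1`) likewise shows only a limit (> 100000 nM), so its place on the numbers is known no more closely than that. For the measured compounds named here, the single measured step (a step that the two limits leave unreadable from compound 1 to compound 2) changed the group on a sulfonamide nitrogen and has no readable size, and both compounds share one limit (the limit of > 100000 nM in this assay, at which 2 of the 2 values shown sit). Compound 3 (`Cc1cc(F)cc(NS(=O)(=O)c2ccc(-c3cnc(C4CC4)o3)cc2)c1`) differs from compound 2 at that same place (3-fluoro-5-methylphenyl in place of 2-chloro-5-methylphenyl on a sulfonamide nitrogen). Going by the values given here, with no sized step to draw on, no change beyond the scatter is expected in this assay, and another limit is the likely report. The expected step is (a number no higher from compound 2 to compound 3 (the limit leaves the size open)). Compound 3 is estimated at (100000 nM), with an expected range of (50000 nM to 200000 nM).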

Compound 3, concentration lethal to 50% of the cells: 78100 nM
Compound 3: the middle estimate sits 1.3-fold (0.11 log units) above what was measured; low and high end bracket the measured number.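

In this assay compound 3, carrying 3-fluoro-5-methylphenyl on the sulfonamide nitrogen, is the only one of the three shown with a number rather than a limit, so a change at this place can bring a reading into the measurable range. The change gives an at least 1.2-fold lower number from compound 2 to compound 3 (0.10 log units; that floor lies within the scatter), and the other comparison gives an at least 1.2-fold lower number from compound 1 to compound 3 (0.10 log units; that floor lies within the scatter); neither floor establishes a change beyond the scatter. Compound 1 and compound 2 remain at a limit: the limit of > 100000 nM in this assay, at which 2 of the 3 values shown sit.

From the compounds shown here alone, the true size of both steps stays open, as does whether an amine or a carboxylic acid in place of the fluorine would move the number beyond the scatter.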